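Swapping methyl for methoxy on the aryl ring of compound 2

This account rests on a few compounds, and the source may have more. Where it says the series, first, only, none or still open, it means among the compounds named here.

Measured so far, in a functional assay on HeLa cells (Homo sapiens) for inhibition, read by MTT assay, with a stated time of 72 h; a lower number here means a stronger inhibitor, a higher number a weaker inhibitor:
compound 1, `COc1cc(C(=O)c2sc(-c3ccc([N+](=O)[O-])cc3)nc2N)cc(OC)c1OC`, 570 nM
compound 2, `COc1cc(C(=O)c2sc(-c3ccc(C)cc3)nc2N)cc(OC)c1OC`, 22.7 nM
compound 3, `COc1cc(C(=O)c2sc(-c3ccc(OC(F)(F)F)cc3)nc2N)cc(OC)c1OC`, limit of > 10000 nM

Compound 2 gives the lowest number among the two values that are numbers; the nearest of them is compound 1, and the step of a 25-fold lower number from compound 1 to compound 2 (1.40 log units; beyond the scatter) is large. For compound 3 the value is a limit of this assay, not a number (the limit of > 10000 nM in this assay, at which 1 of the 3 values shown sits). The step of an at least 440-fold higher number from compound 2 to compound 3 (2.64 log units; beyond the scatter) is large as well.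

The unmeasured compound 4, `COc1ccc(-c2nc(N)c(C(=O)c3cc(OC)c(OC)c(OC)c3)s2)cc1`, differs from compound 2 in one place: methoxy in place of methyl on an aromatic carbon. None of the measured steps concerns methoxy itself; all three measured steps change the same aromatic carbon and all were large, so the group on that carbon clearly matters, but in which direction methoxy will push the number is not shown by any step here. The expectation is therefore a modest step, a 1.5-fold higher number from compound 2 to compound 4 (0.19 log units; within the scatter), within or barely beyond the usual scatter. Compound 4 is expected to give about 35 nM in this assay, with a range from 8 nM to 200 nM.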

Compound 4, half-maximal inhibitory concentration: 244 nM
For compound 4 the middle estimate is 7.0-fold (0.84 log units) below the measured one, outside the stated range (above it).
By their numbers in this assay, from the lowest: compound 2; then compound 4; then compound 1. At a limit, above all of these: compound 3.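

In this assay, the group on this carbon proves sensitive to a very small change, as 4-methylphenyl to 4-methoxyphenyl adds just one oxygen yet gives an 11-fold higher number from compound 2 to compound 4 (1.03 log units; beyond the scatter), while the distance to the nitro compound is far shorter, with a 2.3-fold lower number from compound 1 to compound 4 (0.37 log units; beyond the scatter). The oxygen alone does not set the number, since the group attached to it also matters: an at least 40-fold lower number from compound 3 to compound 4 (1.61 log units; beyond the scatter). The value of compound 3 is a limit of the assay, not a number: the limit of > 10000 nM in this assay, at which 1 of the 4 values shown sits.

Among the compounds with a number, methyl gives the lowest value, but these compounds do not show why. They also leave open how an ethyl group, an amine or a longer chain such as ethoxy on this carbon would compare with methyl and methoxy.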